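From hydroxy to methyl on an aromatic ring

The source may hold more compounds than are shown below. What is called first, only, known or untested is meant among the compounds shown, and "the series" means these compounds.

Among the measured compounds shown here, in a functional assay on LoVo cells (Homo sapiens) for inhibition, read by MTT assay, with a stated time of 24 h (on this read-out lower numbers stand for stronger inhibition and higher numbers for weaker inhibition), compound 3 `CC1(C)[C@H]2CC[C@]1(C)N(Cc1cn(-c3ccccc3O)nn1)C(=O)C2` gives 540 nM, the highest of the three numbers so far, which makes it the weakest inhibitor measured. Compound 1 `CC1(C)[C@H]2CC[C@]1(C)N(Cc1cn(-c3ccc(C#N)cc3)nn1)C(=O)C2` gives 90 nM, and compound 2 `CC1(C)[C@H]2CC[C@]1(C)N(Cc1cn(-c3ccccc3)nn1)C(=O)C2` gives 50 nM. Compound 4 `Cc1ccccc1-n1cc(CN2C(=O)C[C@@H]3CC[C@@]2(C)C3(C)C)nn1` carries methyl in place of hydroxy on an aromatic carbon, ortho to a large group: methyl in place of hydroxy on an aromatic carbon. The closest guide is the large step of an 11-fold higher number from compound 2 to compound 3 (1.03 log units; beyond the scatter), where hydroxy replaces hydrogen. The modest step of a 6.0-fold higher number from compound 1 to compound 3 (0.78 log units; beyond the scatter) also points to a cost from the 2-hydroxyphenyl group. For the measured compounds named here, no measured compound carries methyl, so only part of that gap is expected to close. The expected change is a 3.6-fold lower number from compound 3 to compound 4 (0.56 log units; beyond the scatter), towards stronger inhibition. For compound 4, the estimated value is 150 nM, with an expected range of 40 nM to 600 nM.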

Compound 4, half-maximal inhibitory concentration: 80 nM
Compound 4: the middle estimate sits 1.9-fold (0.27 log units) above what was measured; measured number inside the range.
By their numbers in this assay, from the lowest: compounds 2, 4 and 1 (each within the scatter of the next); then compound 3.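

At this place on the aromatic ring, methyl in place of hydroxy restores a low number (a 6.8-fold lower number from compound 3 to compound 4 (0.83 log units; beyond the scatter)), whereas methyl in place of hydrogen stays within the scatter (a 1.6-fold higher number from compound 2 to compound 4 (0.20 log units; within the scatter)). Among these compounds, then, the high number goes with hydroxy and not with simply having a group at this place. The 2-methylphenyl group also stays within the scatter of the 4-cyanophenyl group (a 1.1-fold lower number from compound 1 to compound 4 (0.05 log units; within the scatter)).

Nothing shown here explains why hydroxy and methyl differ. Going by these compounds, whether methoxy, ethyl or chlorine at this place would behave like methyl or like hydroxy remains open.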